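Replacing the anilide ring on a diaryl-pentyl urea

The source may report more compounds than this note shows. Statements on the series, on what has been measured and on what is new or still open speak of the compounds shown alone.

Compound 1, `O=C(NCCCCC(c1ccc(F)cc1)c1ccc(F)cc1)Nc1ccc(I)cc1`: 11800 nM
Compound 2, `Nc1ccc(NC(=O)NCCCCC(c2ccc(F)cc2)c2ccc(F)cc2)cc1`: > 20000 nM (a limit, not a number)

In a functional assay on MDA-MB-231 cells (Homo sapiens) for cytotoxicity, read by MTT assay, with a stated time of 48 h (on this read-out lower numbers stand for stronger inhibition and higher numbers for weaker inhibition), compound 1 gives 11800 nM. Compound 2 gives > 20000 nM, which is a limit of the assay rather than a measured number; compound 2 therefore sits at the limit of > 20000 nM in this assay, at which 1 of the 2 values shown sits. Going by the values given here, the only measured step, an at least 1.6-fold higher number from compound 1 to compound 2 (0.22 log units; that floor lies within the scatter), runs the other way from the change now considered. Compound 3, `O=C(NCCCCC(c1ccc(F)cc1)c1ccc(F)cc1)Nc1ccc(Cl)cc1C(F)(F)F`, arises through (4-chloro-2-(trifluoromethyl)phenyl in place of 4-aminophenyl on an amide-type nitrogen). Since a halogen-bearing ring, as in compound 1 with 11800 nM, returns, a step of an at least 2.2-fold lower number from compound 2 to compound 3 (0.34 log units; beyond the scatter) downward is expected. Compound 3 is estimated at 9000 nM, between 3000 nM and 25000 nM.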

Compound 3, half-maximal inhibitory concentration: > 20000 nM
Compound 3: no number, only a limit (the forecaster's own chance of this, stated with the estimate: 30%); at least 2.2-fold (0.34 log units) between middle value and limit.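

Compound 3, with a 4-chloro-2-(trifluoromethyl)phenyl group on the amide-type nitrogen, reaches only a limit of the assay in this assay, so halogens on this ring do not by themselves bring back a measured number, as the iodo ring of compound 1 might have suggested. Going by these compounds alone, the one readable comparison is an at least 1.6-fold higher number from compound 1 to compound 3 (0.22 log units; that floor lies within the scatter), and the step between the two limits cannot be read. Compounds in this set now mostly share one limit: the limit of > 20000 nM in this assay, at which 2 of the 3 values shown sit.

Still open, from the compounds shown here alone, is whether a plain 4-chlorophenyl ring, without the trifluoromethyl group, would give a measured number.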